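This account rests on a few compounds, and the source may have more. Where it says the series, first, only, none or still open, it means among the compounds named here.

Measured so far:
- compound 1 `COc1ccc(-c2nc(N)n(-c3ncnc4ccccc34)n2)cc1`: 5000 nM
- compound 2 `Nc1nc(-c2ccccn2)nn1-c1ncnc2cc(OC(F)(F)F)ccc12`: 3000 nM
- compound 3 `COc1cc2ncnc(-n3nc(-c4cccnc4)nc3N)c2cc1OC`: 27000 nM

All three numbers come from a physicochemical assay for solubility, in phosphate buffer, with a stated time of 18 h, at pH 7.4; on this read-out lower numbers stand for lower solubility and higher numbers for higher solubility. Compound 3, at 27000 nM, has the highest number of the three, and its gaps to both of the others lie beyond the scatter. Compound 1 and compound 2 lie within the scatter of each other.

The next compound, compound 4 `COc1cc2ncnc(-n3nc(C4CCCCC4)nc3N)c2cc1OC`, has cyclohexyl in place of pyridin-3-yl on an aromatic carbon. Among the measured compounds shown here, no two measured compounds differ in one place only, so the data offer no direct guide to this swap, and any expectation here is rough. With compound 3 at the top of the measured range at 27000 nM, a fall is likelier than a rise, probably to somewhere near the other two compounds. The expected change is a 6.8-fold lower number from compound 3 to compound 4 (0.83 log units; beyond the scatter). For compound 4 the estimated value is 4000 nM, with an expected range of 1000 nM to 15000 nM.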

Compound 4, solubility: 35000 nM
For compound 4 the middle estimate is 8.8-fold (0.94 log units) below the measured one, outside the stated range (above it).
By their numbers in this assay, from the lowest: compounds 2 and 1 (each within the scatter of the next); then compounds 3 and 4 (each within the scatter of the next).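

Among the compounds shown here, this pair is the first here to differ in one place only, so it gives the first direct reading of a change on an aromatic carbon of the five-membered aromatic ring with 3 nitrogen. In this assay, cyclohexyl in place of pyridin-3-yl gives a 1.3-fold higher number from compound 3 to compound 4 (0.11 log units; within the scatter), so the two compounds cannot be told apart, even though a six-membered aromatic ring with 1 hetero atom and 1 hydrogen-bond acceptor gives way to a non-aromatic ring of carbon only. No measured evidence is at hand that would explain this outcome.

Still open, from the compounds shown here alone, is what an amine, a carboxylic acid or a longer chain would do on this same carbon. Also open, going by these compounds, is whether the same swap would read alike on the core of compound 1 or compound 2.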